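The compounds below may be only part of what the source reports. "The series", "measured", "known", "first", "only" and "open" are said of these compounds alone.

Compound 2, `CC(C)C(=O)Nc1cccc(S(=O)(=O)Oc2ccccc2C(C)C)c1`, carries an isopropylcarbonyl amide on the shared core. In a functional assay on HT-1080 cells (Homo sapiens) for antiproliferative activity, read by sulforhodamine B assay, with a stated time of 48 h (a higher number here means a weaker inhibitor, a lower number a stronger inhibitor), compound 2 gives 16000 nM, which is the higher of the two numbers recorded so far, and its nearest neighbour is compound 1, `CCCC(=O)Nc1cccc(S(=O)(=O)Oc2ccccc2C(C)C)c1`, which in this assay gives 15000 nM. Going by the values given here, the only measured step, a 1.1-fold higher number from compound 1 to compound 2 (0.03 log units; within the scatter), arose from isopropyl in place of propyl on the carbonyl carbon and lies within the scatter, so on the present numbers compound 1 and compound 2 cannot be told apart.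

Compound 3, `CC(C)c1ccccc1OS(=O)(=O)c1cccc(NC(=O)C(C)(C)C)c1`, is the next member of this series. It differs from compound 2 by methyl in place of hydrogen on a saturated chain carbon bound to a carbonyl carbon and two saturated chain carbons. Among the compounds with values here, the one step that bears on this change is the branching of the acyl chain from compound 1 to compound 2, and that step was within the scatter. Within the data shown here, there is no measured step that shows a carbonyl-bound chain growing or branching further to have shifted the number, so no movement beyond the scatter is expected in this assay in either direction; the step from compound 2 to compound 3 is expected to be a 1.1-fold higher number from compound 2 to compound 3 (0.03 log units; within the scatter). Compound 3 is therefore estimated at 17000 nM, with a range from 8000 nM to 36000 nM.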

Compound 3, half-maximal inhibitory concentration: 11000 nM
Estimate against measurement, compound 3: 1.5-fold (0.19 log units) above; the measured number falls inside the stated range.
By their numbers in this assay, from the lowest: compounds 3, 1 and 2 (each within the scatter of the next).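

In this assay, the change from isopropyl to tert-butyl on the carbonyl carbon gives a 1.5-fold lower number from compound 2 to compound 3 (0.16 log units; within the scatter) and adds a further methyl at a chain carbon that already carried branching, a change that the step from compound 1 to compound 2 did not test. The wider comparison of tert-butyl in place of propyl on a carbonyl carbon gives a 1.4-fold lower number from compound 1 to compound 3 (0.13 log units; within the scatter), so the unbranched propyl group and tert-butyl also cannot be told apart here, and all three acyl groups shown remain within the scatter of one another. No available evidence bears on this result.

Whether a longer chain, a phenyl ring or an amine on the carbonyl carbon would move the number beyond the scatter stays open, since the compounds shown carry only propyl, isopropyl and tert-butyl at that place. Also open, as far as these compounds go, is how the number would respond to a change elsewhere on the shared core, such as a carboxylic acid in place of the isopropyl group that all three compounds carry outside the acyl part.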